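This account rests on a few compounds, and the source may have more. Where it says the series, first, only, none or still open, it means among the compounds named here.

Two measured compounds stand in a functional assay on BGC-823 cells (Homo sapiens) for antiproliferative activity, read by MTT assay, with a stated time of 48 h; on this read-out higher numbers stand for weaker inhibition and lower numbers for stronger inhibition. Compound 1 `S=c1oc(-c2ccc3c(c2)OCCO3)nn1CN1CCN(c2cccc(Cl)c2)CC1` gives only a limit of the assay, > 50000 nM. Compound 2 `COc1ccccc1N1CCN(Cn2nc(-c3ccc4c(c3)OCCO4)oc2=S)CC1` gives 19500 nM, the single number shown. Within the data shown here, the one measured step is an at least 2.5-fold lower number from compound 1 to compound 2 (0.40 log units; beyond the scatter), starting from the limit of > 50000 nM in this assay, at which 1 of the 2 values shown sits; it changed both the group and its place on the ring, so its bearing on the present change is loose. Compound 3 `S=c1oc(-c2ccc3c(c2)OCCO3)nn1CN1CCN(c2ccccc2Cl)CC1` differs from compound 2 by chloro in place of methoxy on an aromatic carbon. A step toward weaker inhibition is expected, a 1.8-fold higher number from compound 2 to compound 3 (0.25 log units; within the scatter). Compound 3 is therefore estimated at 35000 nM in this assay, within 12000 nM to 80000 nM.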

Compound 3, half-maximal inhibitory concentration: > 50000 nM
Compound 3: no number, only a limit; the forecaster's own chance of this, stated with the estimate: 35%; middle value at least 1.4-fold (0.15 log units) away from the limit.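

In this assay, chloro in place of methoxy on this aromatic carbon gives an at least 2.5-fold higher number from compound 2 to compound 3 (0.40 log units; beyond the scatter). Unlike the earlier step, this one changes the group at a single place, so it ties the lower number of compound 2 to methoxy rather than to the position alone. The step between compound 1 and compound 3 cannot be read, so the two chloro places remain unranked, and most of the series now sits at a limit: the limit of > 50000 nM in this assay, at which 2 of the 3 values shown sit.

Going by these compounds, it remains open how a hydroxy, ethoxy or amino group on this carbon would compare with methoxy. Also open, on these data alone, is whether methoxy on another ring carbon would keep the value of compound 2.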